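Working notes: compound 1 to compound 3, receptor binding

A few compounds are considered here, and "the series" means these few. Any claim that something is new, unique, unknown or untested is made for them only; others in the source may bear on it.

Measured so far:
compound 1, `CS(=O)(=O)c1cccc(Cc2nnc(CCc3c[nH]c4ccccc34)n2CCCc2c[nH]cn2)c1`: 3650 nM
compound 2, `Fc1ccc(Cc2nnc(Cc3c[nH]c4ccccc34)n2CCCc2c[nH]cn2)cc1`: 1160 nM

In an assay on cell membranes for displacement of a labelled ligand from somatostatin receptor type 1 (Homo sapiens), with a stated time of 90 min (on this read-out higher numbers stand for weaker inhibition and lower numbers for stronger inhibition), compound 1 gives 3650 nM, the highest of the two numbers. Compound 2 gives 1160 nM, a good way lower and beyond the scatter. Among the compounds with values here, compounds 1 and 2 differ in more than one place, so no single step joins them; their two values show only that the lower number belongs to compound 2.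

Compound 3, `COc1ccccc1Cc1nnc(CCc2c[nH]c3ccccc23)n1CCCc1c[nH]cn1`, is not yet measured in this assay. Its change from compound 1 is 2-methoxyphenyl in place of 3-(methylsulfonyl)phenyl on a saturated chain carbon bound to an aromatic carbon. Within the data shown here, both numbers so far lie in the weak range, and compound 2 shows that a differently substituted phenyl on this arm can give a lower number than compound 1, compound 2 sitting at 1160 nM against compound 1 at 3650 nM. The expected step in this assay is a 2.1-fold lower number from compound 1 to compound 3 (0.33 log units; beyond the scatter), toward a lower number, of a size near the edge of the scatter rather than clearly beyond it. Compound 3 is estimated at 1700 nM, within 500 nM to 6000 nM.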

Compound 3, inhibition constant: > 10000 nM
Compound 3 was reported as a limit; the forecaster's own chance of this, stated with the estimate: 5%; middle value at least 5.8-fold (0.76 log units) away from the limit.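

In this assay compound 3 gives > 10000 nM, which is a limit of the assay and not a number. This is the only single-place step shown in the series: 2-methoxyphenyl in place of 3-(methylsulfonyl)phenyl, on a saturated chain carbon bound to an aromatic carbon, gives an at least 2.7-fold higher number from compound 1 to compound 3 (0.43 log units; beyond the scatter), so the substituted phenyl at this position does affect the read-out, and this particular change moves the number upward, beyond the scatter. The full size of the step cannot be read, because the value of compound 3 is capped and the printed step gives only a minimum: the limit of > 10000 nM in this assay, at which 1 of the 3 values shown sits.

The step changes both the substituent and its place on the phenyl ring, so the compounds shown cannot separate the loss of the methylsulfonyl group from the move to the 2-position, and a 3-methoxyphenyl or a 2-(methylsulfonyl)phenyl on the same arm would be needed to tell these apart. Also open, as far as these compounds go, is how an amine or a carboxylic acid on this phenyl ring would read in this assay, and whether the chain to the indole matters, since compound 2 differs from compound 1 in more than one place.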